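One Ring Swap on the Shared Core

A few compounds are considered here, and "the series" means these few. Any claim that something is new, unique, unknown or untested is made for them only; others in the source may bear on it.

Measured in a functional assay on MIA PaCa-2 cells (Homo sapiens) for inhibition, read by MTT assay, with a stated time of 3 days; on this read-out lower numbers stand for stronger inhibition and higher numbers for weaker inhibition:
Compound 1 `CCN(CC)C(=O)[C@@H]1CCCN(S(=O)(=O)c2ccc(S(=O)(=O)N(CC)CC)cc2)C1`: 700 nM
Compound 2 `CCN(CC)S(=O)(=O)c1ccc(S(=O)(=O)N2CCC[C@@H](C(=O)NC3COC3)C2)cc1`: 900 nM
Compound 3 `CCN(CC)S(=O)(=O)c1ccc(S(=O)(=O)N2CCC[C@@H](c3cc(C)no3)C2)cc1`: 2700 nM

Compound 3 gives the highest number of the three, with a 3.0-fold higher number from compound 2 to compound 3 (0.48 log units; beyond the scatter) and a 3.9-fold higher number from compound 1 to compound 3 (0.59 log units; beyond the scatter). Compound 4 `CCN(CC)S(=O)(=O)c1ccc(S(=O)(=O)N2CCC[C@@H](c3nc(C)no3)C2)cc1` differs from compound 3 in one place: 3-methyl-1,2,4-oxadiazol-5-yl in place of 3-methyl-1,2-oxazol-5-yl on a saturated ring carbon. Among the measured compounds shown here, no measured step swaps one small aromatic ring for another; the two steps leading to compound 3 both replaced a diethylcarbamoyl or an (oxetan-3-yl)carbamoyl group by the 3-methyl-1,2-oxazol-5-yl ring, and both were modest. They say little about the present change, so no step beyond the scatter is expected, with a 1.1-fold higher number from compound 3 to compound 4 (0.05 log units; within the scatter). Compound 4 is therefore estimated at 3000 nM, within a range from 1000 nM to 9000 nM.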

Compound 4, half-maximal inhibitory concentration: 700 nM
For compound 4 the middle estimate is 4.3-fold (0.63 log units) above the measured one; measured number outside the range, below it.
By their numbers in this assay, from the lowest: compounds 1, 4 and 2 (each within the scatter of the next); then compound 3.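

In this assay a ring with 3 hetero atoms in place of one with 2 on this saturated ring carbon gives a 3.9-fold lower number from compound 3 to compound 4 (0.59 log units; beyond the scatter) and so shows that the make-up of the ring itself matters here. With a 1.3-fold lower number from compound 2 to compound 4 (0.11 log units; within the scatter) and no change at the digits printed from compound 1 to compound 4 (within the scatter) the 3-methyl-1,2,4-oxadiazol-5-yl ring stands level with both amide groups. Nothing measured here explains the difference between these two rings. Still open, as far as these compounds go, is whether the methyl on this ring matters, and whether an ethyl or a trifluoromethyl in its place would keep the number of compound 4.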